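A few compounds are considered here, and "the series" means these few. Any claim that something is new, unique, unknown or untested is made for them only; others in the source may bear on it.

In a functional assay on HepG2 cells (Homo sapiens) for antiproliferative activity, read by colorimetric assay and MTT assay, with a stated time of 48 h (on this read-out lower numbers stand for stronger inhibition and higher numbers for weaker inhibition), compound 1 (`O=C(NS(=O)(=O)c1ccc(Cl)cc1)c1ccncc1`) gives 7900 nM and compound 2 (`O=C(NS(=O)(=O)c1ccc(Br)cc1)c1ccncc1`) gives 6300 nM on the same read-out. These two values lie within the scatter of each other, so compound 2 stands level with compound 1 and the pair cannot be ranked. Compound 3 (`O=C(NS(=O)(=O)c1ccc(Br)cc1)c1ccccn1`) keeps the bromo group of compound 2 and changes one place: pyridin-2-yl in place of pyridin-4-yl on a carbonyl carbon. Going by the values given here, the only measured step is a 1.3-fold lower number from compound 1 to compound 2 (0.10 log units; within the scatter) and it bears on this change only indirectly, since it swaps chloro for bromo and leaves the pyridin-4-yl untouched. Among the compounds with values here, no measured compound carries the pyridin-2-yl, so the data give no direction for the new change. In this assay no step beyond the scatter is therefore expected, and the expectation rests on compound 2 at 6300 nM as its anchor. The estimated move is a 1.1-fold higher number from compound 2 to compound 3 (0.05 log units; within the scatter) and it is kept small for want of any evidence on direction. Compound 3 is expected at 7000 nM with an estimated range from 2500 nM to 20000 nM as its bounds.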

Compound 3, half-maximal inhibitory concentration: 5000 nM
The estimate for compound 3 lay 1.4-fold (0.15 log units) above the measured number, within the range that was stated.
By their numbers in this assay, from the lowest: compounds 3, 2 and 1 (each within the scatter of the next).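

In this assay, going by these compounds alone, the result gives the first measured reading on the ring held by the carbonyl carbon: pyridin-2-yl in place of pyridin-4-yl produces a 1.3-fold lower number from compound 2 to compound 3 (0.10 log units; within the scatter). The two groups have the same heavy atoms and the same counts of donors and acceptors, so this step tests only how the same atoms are joined, and at this place that change does not take the number beyond the scatter. Alongside a 1.3-fold lower number from compound 1 to compound 2 (0.10 log units; within the scatter), which is the chloro-to-bromo change on an aromatic carbon, both single changes shown so far stay within the scatter, and nothing available explains this result at either place.

On these data alone, it remains open whether a group of a different kind on the carbonyl carbon, such as phenyl, pyridin-3-yl or a chain ending in a carboxylic acid, would move the number beyond the scatter. Also open, as far as these compounds go, is whether an amine or a methoxy group in place of the bromo would do so, and whether pyridin-2-yl gives a similar step when chloro replaces that bromo.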